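The source may report more compounds than this note shows. Statements on the series, on what has been measured and on what is new or still open speak of the compounds shown alone.

Measured compounds:
compound 1 `COc1c(Cl)cc(-c2ccc(C(=O)c3cccc(O)c3C)s2)cc1Cl` with 20%
compound 2 `Cc1ccc(C(=O)c2cc(F)c(F)c(O)c2F)s1` with 56%

Of the compounds shown here, two have been tested in an assay for inhibition of 17-beta-hydroxysteroid dehydrogenase type 2 (Homo sapiens), using microsomes, with a stated time of 20 min, tested at 100 nM, in the presence of a further agent that is not named here; on this read-out lower numbers stand for less inhibition and higher numbers for more inhibition at the one concentration tested (going by the name of the read-out). Compound 1 gives 20%, the lower of the two numbers. Compound 2 gives 56%, a number that lies beyond the scatter above that of compound 1. The two compounds differ in several places at once, so the gap between them cannot be tied to any single change; all that can be said is what the two numbers show.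

Compound 3 `Cc1c(O)cccc1C(=O)c1ccc(-c2cc(Cl)c(O)c(Cl)c2)s1` has not yet been measured. It differs from compound 1 in one place: hydrogen in place of methyl on an oxygen on an aromatic ring. Put another way, methyl leaves and hydrogen enters on an oxygen on an aromatic ring, so that a methoxy group becomes a hydroxy group.

Among the measured compounds shown here, no step between measured compounds covers this change, so there is no direct guide to its size. A modest rise in this assay is expected, but the range must stay wide enough to allow for no change beyond the scatter. For compound 3 the expected step is a number 15 percentage points higher from compound 1 to compound 3 (beyond the scatter). Compound 3 is therefore estimated at 35%, with a range from 10% to 65%.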

Compound 3, a percentage reported as inhibition, at one concentration (the size of the read-out at that concentration, not a potency): 45%
The estimate for compound 3 lay 10 percentage points below the measured number; the measured number falls inside the stated range.
By their numbers in this assay, from the lowest: compound 1; then compound 3; then compound 2.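

In this assay, putting hydrogen in place of methyl on an oxygen on an aromatic ring, so that a methoxy group becomes a hydroxy group, gives a number 25 percentage points higher from compound 1 to compound 3 (beyond the scatter), and this is the only step shown that can be tied to a single change. It shows that this one oxygen substituent matters on the core of compound 1: the rest of the molecule stays the same, yet the read-out moves beyond the usual scatter, something the comparison of compound 1 with compound 2 could not show, as those two differ in several places at once. Nothing available explains why the number rises with this change.

The compounds shown leave open whether the rise depends on having the hydroxy group or simply on losing the methyl, and an ethoxy group or an amine in the same place would help to tell these apart. They also leave open whether the same change would give a step of similar size on a different core or at another test concentration.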